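Working notes: chloro to methoxy on the aryl arm

This account rests on a few compounds, and the source may have more. Where it says the series, first, only, none or still open, it means among the compounds named here.

Compound 1 `O=C1CSC(c2ccccc2)N1n1c(CSc2nnc(-c3ccncc3)o2)nc2ccc(Br)cc2c1=O` gives 31.3% in a functional assay on the whole organism (strain Charles-Foster albino) for inhibition, with Rattus norvegicus as the target, read by paw edema, at a dose of 50 mg/kg by the oral route; on this read-out lower numbers stand for less inhibition and higher numbers for more inhibition at the one dose given (going by the name of the read-out). Compound 2 `O=c1c2cc(Br)ccc2nc(CSc2nnc(-c3ccncc3)o2)n1/N=C/c1ccc(O)cc1` gives 22.3% in this assay, and compound 3 `O=c1c2cc(Br)ccc2nc(CSc2nnc(-c3ccncc3)o2)n1/N=C/c1ccc(Cl)cc1` gives 26.4%. Compound 3 stands second highest of the three numbers; its nearest and its furthest neighbours are given by the steps of a number 4.1 percentage points higher from compound 2 to compound 3 (within the scatter) and a number 4.9 percentage points lower from compound 1 to compound 3 (within the scatter), both within the scatter, so no order among the three compounds can be read from these numbers.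

Compound 4 `COc1ccc(/C=N/n2c(CSc3nnc(-c4ccncc4)o3)nc3ccc(Br)cc3c2=O)cc1` has not yet been measured. It differs from compound 3 in one place: methoxy in place of chloro on an aromatic carbon.

Of the measured steps, the one that bears most directly on this change is the swap of substituents at the same aromatic carbon, a number 4.1 percentage points higher from compound 2 to compound 3 (within the scatter). The two larger replacements on the aromatic nitrogen, a number 9 percentage points lower from compound 1 to compound 2 (within the scatter) and a number 4.9 percentage points lower from compound 1 to compound 3 (within the scatter), also stayed within the scatter. Going by the values given here, nothing among the measured compounds points to a move beyond the scatter on going to methoxy. For compound 4 the expected step is therefore a number 1.4 percentage points lower from compound 3 to compound 4 (within the scatter), no more than the scatter allows. The estimate for compound 4 in this assay is 25%, with a range from 14% to 36%.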

Compound 4, a percentage reported as inhibition, in the whole organism at one dose (the size of the read-out at that dose, not a potency): 24.4%
The estimate for compound 4 lay 0.6 percentage points above the measured number; the measured number falls inside the stated range.
By their numbers in this assay, from the lowest: compounds 2, 4, 3 and 1 (each within the scatter of the next).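

Working notes, result for the methoxy arm: in this assay, the change from 4-chlorophenyl to 4-methoxyphenyl gives a number 2 percentage points lower from compound 3 to compound 4 (within the scatter), and methyl in place of hydrogen on the oxygen gives a number 2.1 percentage points higher from compound 2 to compound 4 (within the scatter), so hydroxy, chloro and methoxy on this aromatic carbon, para to a large group, cannot be told apart on this read-out, even with the added hydrogen-bond acceptor that methoxy brings in place of chloro. The larger replacement on the aromatic nitrogen, with the methoxy arm in place of the group carried by compound 1, gives a number 6.9 percentage points lower from compound 1 to compound 4 (within the scatter), so this arm also stands within the scatter of that group, and all four compounds remain without an order. No measurement is at hand that would account for these numbers lying so close together.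

Still open, on these data alone, is whether any group at this carbon can move the number beyond the scatter, for example an amine, a carboxylic acid or a longer chain such as butoxy. With the one dose given, the series also leaves open whether the close numbers would hold at other doses.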